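Swapping the Aryl Group on the Triazole Across Two Cores

The source may report more compounds than this note shows. Statements on the series, on what has been measured and on what is new or still open speak of the compounds shown alone.

Four compounds share a long unsaturated hydrocarbon chain attached to a tricyclic core, each carrying a five-membered aromatic ring with three nitrogens that bears an aromatic group on one of those nitrogens. Compound 1 `CC(C)=CCC/C(C)=C/CC/C(C)=C/CC[C@@H]1[C@@]2(C)CC/C(=N\OCc3cn(-c4ccccc4C#N)nn3)C(C)(C)[C@@H]2CC[C@@]1(C)O` and compound 2 `CC(C)=CCC/C(C)=C/CC/C(C)=C/CC[C@@H]1[C@@]2(C)CC/C(=N\OCc3cn(-c4cccc([N+](=O)[O-])c4)nn3)C(C)(C)[C@@H]2CC[C@@]1(C)O` link this ring through an oxime ether to the core. In a functional assay on HeLa cells (Homo sapiens) for cytotoxicity, read by MTT assay, with a stated time of 48 h (a higher number here means a weaker inhibitor, a lower number a stronger inhibitor), compound 1 gives 21200 nM, and compound 2 gives 18400 nM. The step of a 1.2-fold lower number from compound 1 to compound 2 (0.06 log units; within the scatter) is described as 3-nitrophenyl in place of 2-cyanophenyl on an aromatic nitrogen.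

Compound 3 `CC(C)=CCC/C(C)=C/CC/C(C)=C/CC[C@@H]1[C@@]2(C)C/C(=C\c3ccc(OCc4cn(-c5ccccc5C#N)nn4)cc3)C(=O)C(C)(C)[C@@H]2CC[C@@]1(C)O` carries the same 2-cyanophenyl-bearing ring, but on a different core, where the ring is attached through a phenyl ether to a carbon double bond beside a carbonyl. The difference between the two cores is not broken down here. In this assay compound 3 gives 100000 nM, the highest of the three measured values and beyond the scatter from both others.

Compound 4 `CC(C)=CCC/C(C)=C/CC/C(C)=C/CC[C@@H]1[C@@]2(C)C/C(=C\c3ccc(OCc4cn(-c5cccc([N+](=O)[O-])c5)nn4)cc3)C(=O)C(C)(C)[C@@H]2CC[C@@]1(C)O` is the not yet measured partner of compound 3, made by the change (3-nitrophenyl in place of 2-cyanophenyl on an aromatic nitrogen), the same kind of change as that from compound 1 to compound 2. Because the earlier step of a 1.2-fold lower number from compound 1 to compound 2 (0.06 log units; within the scatter) stayed within the scatter, the step from compound 3 to compound 4 is expected to be small as well, at a 1.2-fold lower number from compound 3 to compound 4 (0.07 log units; within the scatter). For compound 4 the estimate is 85000 nM, expected to fall between 40000 nM and 150000 nM, with some chance that the assay reports only a limit rather than a number.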

Compound 4, half-maximal inhibitory concentration: 32900 nM
For compound 4 the middle estimate is 2.6-fold (0.41 log units) above the measured one; measured number below the stated range.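

In this assay, putting 3-nitrophenyl in place of 2-cyanophenyl on the aromatic nitrogen gives a 3.0-fold lower number from compound 3 to compound 4 (0.48 log units; beyond the scatter), a modest gain in potency on this core. Set beside the same swap on the core of compound 1, this step does not clearly differ from the earlier one, even though only the newer step stands beyond the scatter on its own: the same change on two cores in this assay, a 1.2-fold lower number (0.06 log units; within the scatter) from compound 1 to compound 2 and a 3.0-fold lower number (0.48 log units; beyond the scatter) from compound 3 to compound 4, 2.6-fold (0.42 log units) apart, within the scatter of two such steps. So the swap can be said to have carried over from one core to the other without a clear change in its size, but two pairs of compounds cannot show that the two steps are truly equal, that the swap would behave the same way on any further core, or why the numbers moved as they did.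

The compounds shown leave open what a plain phenyl, or a phenyl carrying an amine or a carboxylic acid, would do on the same aromatic nitrogen of either core. They also leave open whether the step would hold on a third core, for example one in which an amide link joins the ring with three nitrogens to the rest of the molecule.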